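From a pentyl chain to a methylpiperazine

A few compounds are considered here, and "the series" means these few. Any claim that something is new, unique, unknown or untested is made for them only; others in the source may bear on it.

Measured in a functional assay on MGC-803 cells (Homo sapiens) for inhibition, read by MTT assay, with a stated time of 72 h; a lower number here means a stronger inhibitor, a higher number a weaker inhibitor:
Compound 1 `O=C(Nc1ccccc1)C1CCN(C/C=C/c2ccccc2)CC1` gives 57900 nM
Compound 2 `CCCc1ccc(NC(=O)C2CCN(C/C=C/c3ccccc3)CC2)cc1` gives 5210 nM
Compound 3 `CCCCCc1ccc(NC(=O)C2CCN(C/C=C/c3ccccc3)CC2)cc1` gives 2550 nM

Compound 3 has the lowest number of the three, making it the strongest inhibitor so far. Compound 4 `CN1CCN(c2ccc(NC(=O)C3CCN(C/C=C/c4ccccc4)CC3)cc2)CC1` has 4-methylpiperazin-1-yl in place of pentyl on an aromatic carbon. Adding a chain to compound 1 gave large gains, with an 11-fold lower number from compound 1 to compound 2 (1.05 log units; beyond the scatter) and a 23-fold lower number from compound 1 to compound 3 (1.36 log units; beyond the scatter), while extending the chain gave a modest one, with a 2.0-fold lower number from compound 2 to compound 3 (0.31 log units; beyond the scatter). Among the compounds with values here, no measured compound carries a ring or nitrogen in this position, so the evidence is indirect. A modest loss is expected, with a 3.5-fold higher number from compound 3 to compound 4 (0.55 log units; beyond the scatter) in this assay. The estimate for compound 4 is 9000 nM, with an expected range from 2500 nM to 35000 nM.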

Compound 4, half-maximal inhibitory concentration: 14000 nM
Estimate against measurement, compound 4: 1.6-fold (0.19 log units) below; the measured number falls inside the stated range.
By their numbers in this assay, from the lowest: compound 3; then compound 2; then compound 4; then compound 1.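

At this position, a ring holding nitrogen does worse than either carbon chain (a 5.5-fold higher number from compound 3 to compound 4 (0.74 log units; beyond the scatter); a 2.7-fold higher number from compound 2 to compound 4 (0.43 log units; beyond the scatter)) although it has more heavy atoms than pentyl, so group size alone does not set the number in this assay here. It still improves on hydrogen, with a 4.1-fold lower number from compound 1 to compound 4 (0.62 log units; beyond the scatter) and so all three groups at this position give lower numbers than hydrogen. Nothing available explains why the ring falls short of the chains.

Still open, from the compounds shown here alone, is whether a longer chain such as heptyl would lower the number further. A piperidine or morpholine ring could also show whether the 4-methylpiperazin-1-yl result holds for other rings.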